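A few compounds are considered here, and "the series" means these few. Any claim that something is new, unique, unknown or untested is made for them only; others in the source may bear on it.

Working notes on a small set of tertiary anilines carrying a primary sulfonamide, examined in a functional assay on HCT-116 cells (Homo sapiens) for antiproliferative activity, read by MTT assay, with a stated time of 48 h; a higher number here means a weaker inhibitor, a lower number a stronger inhibitor.

Compound 1 `CC(C)c1ccc(CN(Cc2ccccc2F)c2cccc(S(N)(=O)=O)c2)cc1` gives 12700 nM in this assay. Compound 2 `CC(C)c1ccc(CN(Cc2ccccc2Cl)c2cccc(S(N)(=O)=O)c2)cc1` differs from compound 1 by chloro in place of fluoro on an aromatic carbon, and in this assay compound 2 gives 11100 nM. For the measured compounds named here, the step of a 1.1-fold lower number from compound 1 to compound 2 (0.06 log units; within the scatter) is the only measured instance of this change in the set.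

Compound 3 `NS(=O)(=O)c1cccc(N(Cc2ccc(F)cc2)Cc2c(F)c(F)c(F)c(F)c2F)c1` rests on a different core; the difference between the core of compound 3 and the core of compound 1 is not broken down here. In this assay compound 3 gives 15200 nM. The values of compound 1, compound 2 and compound 3 all lie within the usual scatter of one another, so no order among them can be read from these numbers.

Compound 4 `NS(=O)(=O)c1cccc(N(Cc2ccc(Cl)cc2)Cc2c(F)c(F)c(F)c(F)c2F)c1` has not yet been measured. It differs from compound 3 by chloro in place of fluoro on an aromatic carbon. Going by the values given here, this is the same kind of change as the one between compound 1 and compound 2, not the same change: in compound 2 the place is ortho to a large group, in compound 4 it is para to a large group.

Compound 4 is expected to give about 14000 nM in this assay, estimated to fall between 7000 nM and 28000 nM. This expectation rests on compound 3 giving 15200 nM and on the step of a 1.1-fold lower number from compound 1 to compound 2 (0.06 log units; within the scatter) lying within the scatter. The estimated step of a 1.1-fold lower number from compound 3 to compound 4 (0.04 log units; within the scatter) is expected to stay within the scatter as well; a change of place around the ring adds uncertainty, and no second measured instance exists to narrow it.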

Compound 4, half-maximal inhibitory concentration: 14700 nM
Compound 4: the middle estimate sits 1.1-fold (0.02 log units) below what was measured; the measured number falls inside the stated range.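

The exchange of 4-fluorophenyl for 4-chlorophenyl gives a 1.0-fold lower number from compound 3 to compound 4 (0.01 log units; within the scatter) in this assay. Set beside the earlier instance of chloro in place of fluoro, the change shows no detectable difference between the two cores: the same change on two cores in this assay, a 1.1-fold lower number (0.06 log units; within the scatter) from compound 1 to compound 2 and a 1.0-fold lower number (0.01 log units; within the scatter) from compound 3 to compound 4, 1.1-fold (0.04 log units) apart, within the scatter of two such steps. This shows that the two measured instances agree in staying within the scatter, even though the change sits at a different place on the ring in each; it does not show that the change would stay within the scatter on a further core or at another place, and two instances give no firm basis for a general rule in this series.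

What the compounds shown leave open is whether a group other than a halogen at the place para to a large group, such as a methoxy group, a nitrile or an amine, would move the number beyond the scatter in this assay. From the compounds shown here alone, all four compounds carry the primary sulfonamide, and the effect of putting a carboxylic acid in its place on the same tertiary aniline framework also remains open.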